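A few compounds are considered here, and "the series" means these few. Any claim that something is new, unique, unknown or untested is made for them only; others in the source may bear on it.

Measured in a functional assay on HeLa cells (Homo sapiens) for antiproliferative activity, read by MTT assay, with a stated time of 72 h; on this read-out lower numbers stand for stronger inhibition and higher numbers for weaker inhibition:
compound 1 `C/C=C/C(=O)Nc1cccc(Oc2nc(Nc3cccc(C#N)c3)nc3c2CSCC3)c1` gives 12800 nM
compound 2 `CCC/C=C/C(=O)Nc1cccc(Oc2nc(Nc3cccc(C#N)c3)nc3c2CSCC3)c1` gives 7220 nM
compound 3 `CC(C)/C=C/C(=O)Nc1cccc(Oc2nc(Nc3cccc(C#N)c3)nc3c2CSCC3)c1` gives 22800 nM

Compound 1 cannot be told apart from either of the others, as the series shows a 1.8-fold lower number from compound 1 to compound 2 (0.25 log units; within the scatter) and a 1.8-fold higher number from compound 1 to compound 3 (0.25 log units; within the scatter) in turn. The largest measured step is a 3.2-fold higher number from compound 2 to compound 3 (0.50 log units; beyond the scatter) and stays modest. All three alter the chain on the double-bonded carbon. Compound 4 `C/C=C/C(=O)Nc1cccc(Oc2nc(Nc3ccc(OC)cc3)nc3c2CSCC3)c1` instead differs from compound 1 at the other end of the molecule: 4-methoxyphenyl in place of 3-cyanophenyl on a nitrogen on an aromatic ring in words, 4-methoxyphenyl in place of 3-cyanophenyl on a nitrogen on an aromatic ring. Within the data shown here, no measured step covers this change, so the expectation is weakly founded and no shift beyond the scatter is foreseen. The expected step is a 1.1-fold lower number from compound 1 to compound 4 (0.03 log units; within the scatter) in this case. Compound 4 is estimated at 12000 nM with an expected range from 4000 nM to 40000 nM in this assay here.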

Compound 4, half-maximal inhibitory concentration: > 50000 nM
Compound 4 gave a limit, no number (the forecaster's own chance of this, stated with the estimate: 10%); middle value at least 4.1-fold (0.61 log units) away from the limit.
By their numbers in this assay, from the lowest: compounds 2, 1 and 3 (each within the scatter of the next, the first and the last beyond it). At a limit, above all of these: compound 4.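

Replacing 3-cyanophenyl with 4-methoxyphenyl on a nitrogen on an aromatic ring gives an at least 3.9-fold higher number from compound 1 to compound 4 (0.59 log units; beyond the scatter) in this assay. As far as these compounds go, compound 4 reaches only a limit, > 50000 nM, so the full size of this step stays unknown. The earlier compounds shown here varied only the chain on the double-bonded carbon, whereas this result shows that the read-out also responds to the group at the other end of the molecule.

From the compounds shown here alone, it remains open whether the nitrile or the methoxy group accounts for this step. A plain phenyl, or a phenyl carrying an amine, would help to separate the two.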